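A few compounds are considered here, and "the series" means these few. Any claim that something is new, unique, unknown or untested is made for them only; others in the source may bear on it.

Measured so far in a functional assay on MIA PaCa-2 cells (Homo sapiens) for inhibition, read by MTT assay, with a stated time of 72 h; a lower number here means a stronger inhibitor, a higher number a weaker inhibitor:
Compound 1 `CC(=O)Oc1ccc(C(=O)C2=C(O)[C@]3(CC=C(C)C)C[C@@H](C/C=C(\C)CCC=C(C)C)[C@](C)(CCC=C(C)C)[C@](CC=C(C)C)(C2=O)C3=O)cc1OC(C)=O`: > 20000 nM
Compound 2 `CC(C)=CCC/C(C)=C/C[C@@H]1C[C@]2(CC=C(C)C)C(=O)[C@@](CC=C(C)C)(C(=O)C(C(=O)c3ccc(OCC(=O)O)c(OCC(=O)O)c3)=C2O)[C@@]1(C)CCC=C(C)C`: > 20000 nM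

Compound 2 stands at > 20000 nM, which is a limit of this assay and not a number. Compound 1 gives > 20000 nM, which is also a limit. Among the compounds with values here, the series so far therefore offers only (the limit of > 20000 nM in this assay, at which 2 of the 2 values shown sit), and no measured step shows how far a single change can move the read-out.

Compound 3 `COC(=O)COc1ccc(C(=O)C2=C(O)[C@]3(CC=C(C)C)C[C@@H](C/C=C(\C)CCC=C(C)C)[C@](C)(CCC=C(C)C)[C@](CC=C(C)C)(C2=O)C3=O)cc1OCC(=O)O` keeps the core of compound 2 and differs from it in one place: methyl in place of hydrogen on an oxygen next to a carbonyl group. This is methyl in place of hydrogen on an oxygen next to a carbonyl group, which turns a carboxymethyl into a (methoxycarbonyl)methyl.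

With compound 2 at the limit of > 20000 nM, only a modest shift toward stronger inhibition in this assay is expected, and possibly none that can be seen. The expected size of the change is a number no higher from compound 2 to compound 3 (the limit leaves the size open), and this is an estimate only. For compound 3 the estimated value is 20000 nM, with an expected range of 9000 nM to 40000 nM.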

Compound 3, half-maximal inhibitory concentration: > 20000 nM
Compound 3 was reported as a limit (the forecaster's own chance of this, stated with the estimate: 65%); the middle value sits exactly at the limit.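

In this assay compound 3 gives > 20000 nM as a limit of the assay and not a number. Within the data shown here, compound 2 also stands at a limit, so the change from compound 2 to compound 3 gives no step that can be read. The compounds shown leave open how strongly any of them inhibits and how far a single change can move the read-out, with one result throughout: the limit of > 20000 nM in this assay, at which 3 of the 3 values shown sit.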